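Sulfamoyl-piperidine amidoximes: phenyl on the sulfonamide nitrogen

A few compounds are considered here, and "the series" means these few. Any claim that something is new, unique, unknown or untested is made for them only; others in the source may bear on it.

Measured compounds:
compound 1 `NS(=O)(=O)N1CCC(C(=O)/C(=N/O)Nc2ccc(F)c(Br)c2)CC1` gives 62500 nM in an assay for inhibition of Tryptophan 2,3-dioxygenase (Homo sapiens), with a stated time of 1 h; on this read-out lower numbers stand for stronger inhibition and higher numbers for weaker inhibition;
compound 2 `O=C(NC[C@H]1CC[C@H](C(=O)/C(=N/O)Nc2ccc(F)c(Br)c2)CC1)c1ccccc1` gives 81000 nM in this assay;
compound 3 `O/N=C(/CC1CCCCC1)Nc1ccc(F)c(Br)c1` gives > 100000 nM in this assay, which is a limit of the assay and not a number.

Compound 1 has the lowest of the two numbers available, with compound 2 close behind and within the scatter, so no order between the two can be read. Compound 3 sits at the limit, (the limit of > 100000 nM in this assay, at which 1 of the 3 values shown sits), and gives no number. Both compound 1 and compound 2 carry the shared core with a piperidine or cyclohexane ring bearing a polar substituent; the larger benzamide extension of compound 2 does not move the number beyond the scatter from compound 1.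

Compound 4 `O=C(/C(=N/O)Nc1ccc(F)c(Br)c1)C1CCN(S(=O)(=O)Nc2ccccc2)CC1` is not yet measured. It differs from compound 1 by phenyl in place of hydrogen on a sulfonamide nitrogen. Among the measured compounds shown here, no step between measured compounds addresses this change directly; the nearest comparison, compound 1 against compound 2, shows that adding an aromatic ring to the polar substituent does not change the number beyond the scatter. The step from compound 1 to compound 4 is therefore expected to be small, possibly a slight gain, a 1.4-fold lower number from compound 1 to compound 4 (0.14 log units; within the scatter). For compound 4 the estimate in this assay is 45000 nM, with a range from 12000 nM to 150000 nM.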

Compound 4, half-maximal inhibitory concentration: 65700 nM
The estimate for compound 4 lay 1.5-fold (0.16 log units) below the measured number, within the range that was stated.
By their numbers in this assay, from the lowest: compounds 1, 4 and 2 (each within the scatter of the next). At a limit, above all of these: compound 3.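

In this assay, among the compounds shown here, the change on the sulfonamide nitrogen gives a 1.1-fold higher number from compound 1 to compound 4 (0.02 log units; within the scatter) and is the only step that can be read in one place. Phenyl in place of hydrogen on this nitrogen therefore leaves the number within the scatter, so the position accepts an aromatic ring of carbon only with neither a gain nor a loss that can be read, and the sulfamoyl to phenylsulfamoyl change offers no handle on the number so far. Nothing measured here accounts for the size of this step.

Going by these compounds, whether any other group on this nitrogen moves the number stays open, as a single step says nothing about a methyl, a benzyl, or a phenyl ring carrying a carboxylic acid or an amine. For the compounds shown here, also open is whether the number responds to changes elsewhere on the shared core, such as replacing the bromine of the anilino ring with a chlorine or a nitrile, since no step at any other position can be read.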